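From methyl to isopropyl on the chain carbon

The compounds below may be only part of what the source reports. "The series", "measured", "known", "first", "only" and "open" are said of these compounds alone.

Measured compounds:
Compound 1 `C[C@H](Nc1ncnc2[nH]cnc12)c1nn(-c2cccnc2)c2cc(F)ccc12`: 37500 nM
Compound 2 `C[C@H](Nc1ncnc2[nH]cnc12)c1nn(-c2ccncc2)c2cc(F)ccc12`: 23100 nM

Both values come from a functional assay on HepG2 cells (Homo sapiens) for inhibition, read by sulforhodamine B assay, with a stated time of 72 h; on this read-out higher numbers stand for weaker inhibition and lower numbers for stronger inhibition. For the measured compounds named here, compound 1 stands level with compound 2, the only other compound measured, since the single measured step is a 1.6-fold lower number from compound 1 to compound 2 (0.21 log units; within the scatter). That step exchanges pyridin-3-yl for pyridin-4-yl on an aromatic nitrogen, a different place from the change considered here. Compound 3 `CC(C)[C@H](Nc1ncnc2[nH]cnc12)c1nn(-c2cccnc2)c2cc(F)ccc12` departs from compound 1 by isopropyl in place of methyl on a saturated chain carbon bound to an aromatic carbon and a nitrogen on an aromatic ring. Going by the values given here, no measured pair tests a change at this chain carbon, so the data give no direct guide to its size or direction. With that one small step as the only reference, no shift beyond the scatter is expected in this assay. The expected change is a 1.3-fold lower number from compound 1 to compound 3 (0.10 log units; within the scatter). Compound 3 is estimated at 30000 nM, with an expected range from 10000 nM to 70000 nM.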

Compound 3, half-maximal inhibitory concentration: > 40000 nM
Compound 3: no number, only a limit; the forecaster's own chance of this, stated with the estimate: 15%; middle value at least 1.3-fold (0.12 log units) away from the limit.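

In this assay compound 3 returns a limit and not a number: the limit of > 40000 nM in this assay, at which 1 of the 3 values shown sits.

For the compounds shown here, this gives the first reading at the saturated chain carbon, where isopropyl in place of methyl yields an at least 1.0-fold higher number from compound 1 to compound 3 (0.02 log units; that floor lies within the scatter). The exchange therefore brought no lower number within the range of this assay, although the floor of the step does not set compound 3 apart from compound 1.

The compounds shown leave open how far compound 3 truly lies from compound 1, and what ethyl or an amine would do at this chain carbon. They also leave open whether isopropyl would behave the same way with the pyridin-4-yl group of compound 2 on the aromatic nitrogen.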